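The compounds below may be only part of what the source reports. "The series", "measured", "known", "first", "only" and "open" are said of these compounds alone.

Measured so far:
compound 1 `CC(C)c1cccc(C(C)C)c1NC(=O)NC(=O)Nc1c(C(C)C)cccc1C(C)C`: > 5000 nM
compound 2 `CC(C)c1cccc(C(C)C)c1NC(=O)NC(=O)N(c1ccccc1)c1ccccc1`: 340 nM

Going by the values given here, in an assay on microsomes from intestine for inhibition of acyl-CoA:cholesterol acyltransferase (Oryctolagus cuniculus) (on this read-out higher numbers stand for weaker inhibition and lower numbers for stronger inhibition), compound 2 gives 340 nM, the only number in the set. Compound 1 gives only > 5000 nM, which is a limit of the assay and not a number (the limit of > 5000 nM in this assay, at which 1 of the 2 values shown sits). Compound 3 `CC(C)c1cccc(C(C)C)c1NC(=O)N(C)C(=O)N(c1ccccc1)c1ccccc1` differs from compound 2 by methyl in place of hydrogen on an amide-type nitrogen. Among the compounds with values here, no measured pair shows this change, so its size is not known from the data. Compound 3 is expected at 800 nM, within 250 nM to 4000 nM. The expected step of a 2.4-fold higher number from compound 2 to compound 3 (0.37 log units; beyond the scatter) points toward weaker inhibition, beyond the scatter.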

Compound 3, half-maximal inhibitory concentration: 440 nM
The estimate for compound 3 lay 1.8-fold (0.26 log units) above the measured number, and the stated range covers the measured number.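

In this assay, methyl in place of hydrogen on the amide-type nitrogen whose other neighbours are both carbonyl carbons gives a 1.3-fold higher number from compound 2 to compound 3 (0.11 log units; within the scatter). In this one pair, then, the hydrogen on this nitrogen can be replaced by methyl without a step beyond the scatter. The data at hand offer no explanation for this result.

Going by these compounds, whether the same holds for a group larger than methyl on this nitrogen, such as ethyl or benzyl, remains open. So does the outcome for a longer chain ending in an amine or a carboxylic acid.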